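Succinimide propanamides: chloro to trifluoromethyl on the benzyl ring

This account rests on a few compounds, and the source may have more. Where it says the series, first, only, none or still open, it means among the compounds named here.

The series shares one core, a succinimide-bearing propanamide linked to a substituted benzyl amide. Compound 1 `CC(C(=O)NCc1cccc(Cl)c1)N1C(=O)CCC1=O` carries chloro on the aromatic ring; in a functional assay on the whole organism (strain Albino Swiss CD1) with Mus musculus as the target (on this read-out higher numbers stand for an effect only at larger amounts of compound and lower numbers for an effect already at smaller amounts), compound 1 gives "not determined" (no result reported). Compound 2 `CC(C(=O)NCc1ccc(Cl)cc1)N1C(=O)CCC1=O` moves the chloro to a different position of the ring; in this assay compound 2 gives 43.6 mg/kg. Going by the values given here, this is the only number, so compound 2 stands alone on the read-out and no measured step between compounds exists.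

Compound 3 `CC(C(=O)NCc1ccc(C(F)(F)F)cc1)N1C(=O)CCC1=O` differs from compound 2 by trifluoromethyl in place of chloro on an aromatic carbon. Exchanges of this kind between two halogen-type aromatic substituents have no precedent within these compounds, so the expectation rests on the single value of compound 2 alone. The step from compound 2 to compound 3 is expected to be small, a 1.3-fold higher number from compound 2 to compound 3 (0.10 log units; within the scatter), that is, within or only slightly beyond the scatter, with a lean toward a somewhat larger dose. For compound 3 the dose in this assay is therefore estimated at 55 mg/kg, with a range from 20 mg/kg to 150 mg/kg.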

Compound 3, dose for half-maximal effect: 54.5 mg/kg
Estimate against measurement, compound 3: 1.0-fold (0.00 log units) above; measured number inside the range.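

In this assay, trifluoromethyl in place of chloro on an aromatic carbon, para to a large group, gives a 1.3-fold higher number from compound 2 to compound 3 (0.10 log units; within the scatter), so compound 2 and compound 3 cannot be told apart on this read-out. Going by these compounds alone, this is the first readable step, and it shows that at this position the single chlorine atom can be replaced by the carbon and three fluorines of trifluoromethyl with no change beyond the usual scatter. Within the data shown here, neither group brings a hydrogen-bond donor, a hydrogen-bond acceptor or a net charge, so the step tests only this one exchange, and no measurement of any property of the two groups accompanies it to account for the result.

Going by these compounds, whether this tolerance extends to a substituent of another kind at the same place, such as an amine, a carboxylic acid or a methoxy group, stays open. Steps involving compound 1 cannot be read, so the compounds shown also leave open how the dose depends on where the substituent sits on the ring.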